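The source may report more compounds than this note shows. Statements on the series, on what has been measured and on what is new or still open speak of the compounds shown alone.

The shared core of this set appears in compound 1 `CNC(=O)c1cc(C(=O)NC2CC2)cn(Cc2ccc(C)cc2)c1=O`, which in a physicochemical assay for solubility (a higher number here means a more soluble compound, a lower number a less soluble compound), gives 24 ug/mL. That is the only plain number among the three results shown, so compound 1 stands as the single measured value with no other number beside it to rank against. Compound 2 `CNC(=O)c1cc(C(=O)NCCC2CCOCC2)cn(Cc2ccccc2)c1=O` in this assay gives >= 127 ug/mL, which is a limit of the assay and not a number. Compound 3 `CNC(=O)c1cc(C(=O)NC2CCC2)cn(Cc2ccccn2)c1=O` in this assay gives >= 103 ug/mL, likewise a limit of the assay rather than a number. Going by the values given here, no two of these measured compounds differ in one place, so no measured step is available. Compound 4 `CNC(=O)c1cc(C(=O)NC2CC2)cn(Cc2ccc3nc[nH]c3c2)c1=O` has not been measured; it differs from compound 1 by 1H-benzimidazol-6-yl in place of 4-methylphenyl on a saturated chain carbon bound to an aromatic nitrogen. For this change the expectation is an upward step in this assay, larger than the usual scatter, toward higher solubility. Compound 4 is therefore estimated at 70 ug/mL, with a range from 20 ug/mL to 200 ug/mL, an expected step of a 2.9-fold higher number from compound 1 to compound 4 (0.46 log units; beyond the scatter).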

Compound 4, solubility: >= 163 ug/mL
Compound 4 gave a limit, no number; the forecaster's own chance of this, stated with the estimate: 30%; middle value at least 2.3-fold (0.36 log units) from the limit.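

Going by these compounds alone, compound 1 and compound 4 form the first pair in this set that differs in one place, so the effect of a change at this position can now be read on its own. In this assay, 1H-benzimidazol-6-yl in place of 4-methylphenyl, on a saturated chain carbon bound to an aromatic nitrogen, gives an at least 6.7-fold higher number from compound 1 to compound 4 (0.83 log units; beyond the scatter). Compound 4 gives a limit of the assay and not a number: the limit of >= 163 ug/mL in this assay, at which 1 of the 4 values shown sits.

From the compounds shown here alone, how far the true value of compound 4 lies from its limit remains open, and so does the full size of the step. Also open, going by these compounds, is whether the step belongs to the two ring nitrogens or to the second ring, which an indolyl group or a phenyl ring carrying an amine at this position could help to separate.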